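Amide Variation on a Naphthyl-Pyridine Acrylamide Series

A few compounds are considered here, and "the series" means these few. Any claim that something is new, unique, unknown or untested is made for them only; others in the source may bear on it.

The shared core of these compounds carries an acrylamide whose amide portion varies. Among the measured compounds shown here, compound 1 `O=C(/C=C/c1ccncc1-c1ccc2ccccc2c1)NC1CC1` is the only one with a number: in a functional assay on HCT-116 cells (Homo sapiens) for inhibition, read by MTT assay, with a stated time of 72 h (on this read-out higher numbers stand for weaker inhibition of growth and lower numbers for stronger inhibition of growth), compound 1 gives 6180 nM. Compound 2 `O=C(O)[C@@H]1CCCN1C(=O)/C=C/c1ccncc1-c1ccc2ccccc2c1` has no result in this assay, where compound 2 stands as "not determined" (no result reported). Compound 3 `O=C(O)CCNC(=O)/C=C/c1ccncc1-c1ccc2ccccc2c1` likewise stands in this assay as "not determined" (no result reported), so compound 3 has no number to build on. Compound 4 `CN1CCN(C(=O)/C=C/c2ccncc2-c2ccc3ccccc3c2)CC1` differs from compound 3 in one place: 4-methylpiperazin-1-yl in place of (2-carboxyethyl)amino on a carbonyl carbon. With no step between measured compounds shown, no direction can be taken from compound 3, and only the result of compound 1 gives a scale. Compound 4 is therefore expected to give about 5000 nM in this assay, within 1500 nM to 20000 nM.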

Compound 4, concentration for 50% growth inhibition: > 30000 nM
Compound 4 ended at the assay's limit (the forecaster's own chance of this, stated with the estimate: 25%); at least 6.0-fold (0.77 log units) between middle value and limit.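

Among the compounds shown here, compound 1 had given the only number at this position. The new result shows that the group on this carbonyl carbon can change the read-out in this assay, with 4-methylpiperazin-1-yl in place of cyclopropylamino giving an at least 4.8-fold higher number from compound 1 to compound 4 (0.68 log units; beyond the scatter). Compound 4 stands at a limit of the assay, not at a number: the limit of > 30000 nM in this assay, at which 1 of the 4 values shown sits.

The ring, its second nitrogen and the methyl enter together, and the compounds shown leave open which of them carries the change. A piperidine, a morpholine or an open-chain dimethylamino group on the same carbonyl carbon would separate them.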